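A single aryl swap on the urea nitrogen

A few compounds are considered here, and "the series" means these few. Any claim that something is new, unique, unknown or untested is made for them only; others in the source may bear on it.

In a functional assay on NCI-H460 cells (Homo sapiens) for inhibition, read by MTT assay, with a stated time of 72 h (on this read-out lower numbers stand for stronger inhibition and higher numbers for weaker inhibition), compound 3 `COc1cc(NC(C)CCCNC(=O)NNC(=O)Nc2ccc(Br)cc2)c2ncccc2c1` gives 27000 nM, the second highest of the three numbers shown. Compound 1 `COc1cc(NC(C)CCCNC(=O)NNC(=O)Nc2cccc(F)c2)c2ncccc2c1` gives 50000 nM, and compound 2 `COc1cc(NC(C)CCCNC(=O)NNC(=O)Nc2cc(C(F)(F)F)cc(C(F)(F)F)c2)c2ncccc2c1` gives 18000 nM; both lie within the scatter of compound 3. Within the data shown here, compound 4 `COc1cc(NC(C)CCCNC(=O)NNC(=O)Nc2cccc(C(F)(F)F)c2)c2ncccc2c1` has not yet been measured. 3-(trifluoromethyl)phenyl in place of 4-bromophenyl on an amide-type nitrogen The one measured step of the same kind, a 1.9-fold lower number from compound 1 to compound 3 (0.27 log units; within the scatter), stayed within the scatter, and compound 2, which also carries trifluoromethyl on the same ring, sits within the scatter of compound 3. No change beyond the scatter is therefore expected, though the values of compound 2 and compound 3 point to a slightly lower number. Compound 4 is estimated at 22000 nM, with a range of 9000 nM to 50000 nM, meaning an expected step of a 1.2-fold lower number from compound 3 to compound 4 (0.09 log units; within the scatter).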

Compound 4, half-maximal inhibitory concentration: 20000 nM
Beside the measured number, compound 4's estimate is 1.1-fold (0.04 log units) above it, within the range that was stated.
By their numbers in this assay, from the lowest: compounds 2, 4, 3 and 1 (each within the scatter of the next, the first and the last beyond it).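

In this assay, the change on an amide-type nitrogen gives a 1.4-fold lower number from compound 3 to compound 4 (0.13 log units; within the scatter), so exchanging 4-bromophenyl for 3-(trifluoromethyl)phenyl does not move the number beyond the scatter. Hydrogen in place of trifluoromethyl on an aromatic carbon likewise stays within it, with a 1.1-fold higher number from compound 2 to compound 4 (0.05 log units; within the scatter). Trifluoromethyl in place of fluoro gives a 2.5-fold lower number from compound 1 to compound 4 (0.40 log units; beyond the scatter), a modest step and the first single-place change shown here to pass the scatter. Nothing measured here accounts for this step. Going by these compounds, whether an amine or a carboxylic acid on this ring would give a larger step remains open.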